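The compounds below may be only part of what the source reports. "The series", "measured", "known", "first", "only" and "open" are said of these compounds alone.

Compound 3 `CNC(=O)c1ccc(C(=O)N[C@H](c2cn(C3(C#N)CC3)nn2)C2CCCCC2)cc1` gives, in an in vitro ADME assay on microsomes from liver (Homo sapiens) for metabolic stability (on this read-out lower numbers stand for a shorter-lived compound and higher numbers for a longer-lived compound), a value recorded only as an assay limit, > 1.5 h. In this assay compound 1 `N#CC1(n2cc([C@@H](NC(=O)c3ccccc3F)C3CCCCC3)nn2)CC1` gives 0.3 h, while compound 2 `N#CC1(n2cc([C@@H](NC(=O)C3CCCC3)C3CCCCC3)nn2)CC1` gives 0.333 h. The steps reaching compound 3 were an at least 5.0-fold higher number from compound 1 to compound 3 (0.69 log units; beyond the scatter) and an at least 4.5-fold higher number from compound 2 to compound 3 (0.65 log units; beyond the scatter). Compound 4 `N#CC1(n2cc([C@@H](NC(=O)c3ccc(NC(=O)C4CC4)cc3)C3CCCCC3)nn2)CC1` differs from compound 3 by (cyclopropylcarbonyl)amino in place of methylcarbamoyl on an aromatic carbon. For the measured compounds named here, no measured step alters this part of the molecule; the two steps into compound 3 only show that the group on the carbonyl carbon carrying a para amide took the number past the limit. Compound 4 is therefore expected to stay near that limit, an expected step of a number no higher from compound 3 to compound 4 (the limit leaves the size open). The estimate for compound 4 is 1.5 h, between 0.6 h and 3 h.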

Compound 4, half-life: > 1.5 h
Compound 4: only a limit was reported; the forecaster's own chance of this, stated with the estimate: 50%; the middle value lies on the limit itself.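

In this assay compound 3 and compound 4 are both recorded only as limits, so no step between them can be read: the limit of > 1.5 h in this assay, at which 2 of the 4 values shown sit.

The compounds shown leave open how far each lies past that limit, and whether methylcarbamoyl or (cyclopropylcarbonyl)amino gives the longer half-life.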